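Ring Size at the Chain End and Cytotoxicity

This account rests on a few compounds, and the source may have more. Where it says the series, first, only, none or still open, it means among the compounds named here.

Compound 1 `COc1cc2c(Nc3nc4ccc(C(=O)Nc5c(C)cccc5C)cc4s3)ncnc2cc1OCCCN1CCCC1` gives 83800 nM in a functional assay on A549 cells (Homo sapiens) for cytotoxicity, read by WST assay, with a stated time of 72 h; a lower number here means a stronger inhibitor, a higher number a weaker inhibitor.
Compound 2 `COc1cc2c(Nc3nc4ccc(C(=O)Nc5c(C)cccc5C)cc4s3)ncnc2cc1OCCCN1CCCCC1` reaches only a limit of this assay, > 100000 nM.
Compound 3 `COc1cc2c(Nc3nc4ccc(C(=O)Nc5c(C)cc(C)cc5C)cc4s3)ncnc2cc1OCCCN1CCCCC1` gives 10300 nM in this assay.

The three measured compounds share one core and differ in two places. Compound 2 and compound 3 differ by methyl in place of hydrogen on an aromatic carbon, and this step gives an at least 9.7-fold lower number from compound 2 to compound 3 (0.98 log units; beyond the scatter). Compound 2 and compound 1 differ by pyrrolidin-1-yl in place of piperidin-1-yl on a saturated chain carbon, three bonds along the chain from an oxygen on an aromatic ring, and this step gives an at least 1.1-fold lower number from compound 2 to compound 1 (0.07 log units; that floor lies within the scatter). Compound 3 thus gives the lowest of the two numbers in this assay; the number for compound 1 stands higher, and the value for compound 2 is a limit rather than a number (the limit of > 100000 nM in this assay, at which 1 of the 3 values shown sits).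

Compound 4 `COc1cc2c(Nc3nc4ccc(C(=O)Nc5c(C)cc(C)cc5C)cc4s3)ncnc2cc1OCCCN1CCCC1` has not yet been measured in this assay. It differs from compound 3 by pyrrolidin-1-yl in place of piperidin-1-yl on a saturated chain carbon, three bonds along the chain from an oxygen on an aromatic ring. Going by the values given here, this is the same change as the one from compound 2 to compound 1, made at the same place. Since the earlier step, an at least 1.1-fold lower number from compound 2 to compound 1 (0.07 log units; that floor lies within the scatter), lies at a floor within the usual scatter, compound 3 and compound 4 are expected to differ little, and the step of a 1.2-fold lower number from compound 3 to compound 4 (0.08 log units; within the scatter) is expected to be small. Compound 4 is therefore estimated at 8500 nM in this assay, with the expected range running from 3000 nM to 25000 nM.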

Compound 4, half-maximal inhibitory concentration: 8900 nM
Compound 4: middle estimate off by 1.0-fold (0.02 log units), on the low side; measured number inside the range.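

In this assay the change of ring at the chain end gives a 1.2-fold lower number from compound 3 to compound 4 (0.06 log units; within the scatter), while methyl in place of hydrogen on an aromatic carbon gives a 9.4-fold lower number from compound 1 to compound 4 (0.97 log units; beyond the scatter). The ring change is small where it can be read in full, but with compound 2 standing at a limit, the four compounds do not show that it has the same size on both cores: the same change on two cores in this assay, an at least 1.1-fold lower number (0.07 log units; that floor lies within the scatter) from compound 2 to compound 1 and a 1.2-fold lower number (0.06 log units; within the scatter) from compound 3 to compound 4; the limit leaves it open whether they differ. The methyl step is beyond the scatter on the core of compound 1, and the earlier step fits it, yet that earlier step is only a floor, so the series supports a carry-over of the methyl effect in direction without fixing its size on both cores: the same change on two cores in this assay, an at least 9.7-fold lower number (0.98 log units; beyond the scatter) from compound 2 to compound 3 and a 9.4-fold lower number (0.97 log units; beyond the scatter) from compound 1 to compound 4; the limit leaves it open whether they differ.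

The compounds shown leave open whether the small ring step would also hold for a morpholine or a piperazine at the chain end, or with a chain shorter or longer than the one in 3-(pyrrolidin-1-yl)propyl. They also leave open whether a chlorine or a fluorine in place of the added methyl would lower the number as the methyl does, and whether either step would hold in any test other than this assay.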